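A Smaller Amine on the Chain of Compound 1

The compounds below may be only part of what the source reports. "The series", "measured", "known", "first", "only" and "open" are said of these compounds alone.

Compound 1 `CN1CCN(CCCCCn2c3c(c4ccccc42)C(=O)c2c[n+]([O-])c4ccccc4c2C3=O)CC1` was measured in a functional assay on SH-SY5Y cells (Homo sapiens) for cytotoxicity, read by MTT assay, with a stated time of 72 h (a higher number here means a weaker inhibitor, a lower number a stronger inhibitor), where compound 1 gives 830 nM. Compound 3 `O=C1c2c[n+]([O-])c3ccccc3c2C(=O)c2c1c1ccccc1n2CCCCN1CCCCC1` gives 230 nM in this assay. For compound 2 `O=C1c2c[n+]([O-])c3ccccc3c2C(=O)c2c1c1ccccc1n2Cc1cn(CC(O)CO)nn1` this assay reports only a limit, > 1000 nM. Among the two numbers shown, compound 1 carries the highest; compound 3, the nearest, sits below it by a 3.6-fold lower number from compound 1 to compound 3 (0.56 log units; beyond the scatter). Compound 2 sits at the limit of > 1000 nM in this assay, at which 1 of the 3 values shown sits. Compound 4 `CN(C)CCCCn1c2c(c3ccccc31)C(=O)c1c[n+]([O-])c3ccccc3c1C2=O` has not yet been measured in this assay. It differs from compound 1 as follows: dimethylamino in place of (4-methylpiperazin-1-yl)methyl on a saturated chain carbon, four bonds along the chain from an aromatic nitrogen. Of the measured steps only a 3.6-fold lower number from compound 1 to compound 3 (0.56 log units; beyond the scatter) bears directly on this change, for it also replaces (4-methylpiperazin-1-yl)methyl at the same place with another amine. The other step, an at least 1.2-fold higher number from compound 1 to compound 2 (0.08 log units; that floor lies within the scatter), exchanges the whole chain and ends at a limit, so it says little here. Compound 4 is therefore expected to show a modestly lower number than compound 1, a 1.7-fold lower number from compound 1 to compound 4 (0.22 log units; within the scatter), though the step may also fall within the scatter. Compound 4 is estimated at 500 nM, with a range from 200 nM to 1500 nM.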

Compound 4, half-maximal inhibitory concentration: 250 nM
Beside the measured number, compound 4's estimate is 2.0-fold (0.30 log units) above it; low and high end bracket the measured number.
By their numbers in this assay, from the lowest: compounds 3 and 4 (each within the scatter of the next); then compound 1. At a limit, above all of these: compound 2.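

In this assay, dimethylamino in place of (4-methylpiperazin-1-yl)methyl gives a 3.3-fold lower number from compound 1 to compound 4 (0.52 log units; beyond the scatter), so at this place a lower number is reached with an amine carrying no ring as well as with the piperidin-1-yl of compound 3. The two smaller amines cannot be told apart, with a 1.1-fold higher number from compound 3 to compound 4 (0.04 log units; within the scatter), although only one of them has a ring. The step from the chain bearing 1-(2,3-dihydroxypropyl)-1H-1,2,3-triazol-4-yl is only a floor, an at least 4.0-fold lower number from compound 2 to compound 4 (0.60 log units; beyond the scatter), since its starting value is a limit.

The compounds shown leave open whether morpholine, diethylamino or an unsubstituted piperazine at this place would fall with compound 3 and compound 4 or with compound 1. They also leave open how a shorter or longer chain carrying dimethylamino would read.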